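The compounds below may be only part of what the source reports. "The series", "measured", "known", "first", "only" and "open" are said of these compounds alone.

Measured so far in a functional assay on L6 cells (Rattus norvegicus) for inhibition; a higher number here means a weaker inhibitor, a lower number a stronger inhibitor:
- compound 1 `Cc1ccc(CNC(=O)c2nn(-c3ccc(F)cc3)c(CC[C@@H](O)C[C@@H](O)CC(=O)O)c2C(C)C)cc1` gives 800 nM
- compound 2 `CCN(Cc1ccccc1)C(=O)c1nn(-c2ccc(F)cc2)c(OC[C@@H](O)C[C@@H](O)CC(=O)O)c1C(C)C` gives 2660 nM

Compound 2 (at 2660 nM) has the higher of the two numbers, and its gap to compound 1 lies beyond the scatter. Compound 3 `CC(C)c1c(C(=O)NCc2cccc(F)c2F)nn(-c2ccc(F)cc2)c1OC[C@@H](O)C[C@@H](O)CC(=O)O` has not yet been measured. It carries (2,3-difluorobenzyl)amino in place of benzyl(ethyl)amino on a carbonyl carbon. For the measured compounds named here, no measured step isolates this change, so the only guide is compound 1 (at 800 nM), which points weakly towards a lower number in this assay. A small downward step a 1.9-fold lower number from compound 2 to compound 3 (0.28 log units; within the scatter) is expected, possibly no larger than the scatter. Compound 3 is estimated at 1400 nM (expected range 400 nM to 4500 nM).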

Compound 3, half-maximal inhibitory concentration: 120 nM
Compound 3: the middle estimate sits 12-fold (1.07 log units) above what was measured; measured number below the stated range.
By their numbers in this assay, from the lowest: compound 3; then compound 1; then compound 2.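

In this assay the group on the carbonyl carbon proves highly sensitive: (2,3-difluorobenzyl)amino in place of benzyl(ethyl)amino gives a 22-fold lower number from compound 2 to compound 3 (1.35 log units; beyond the scatter) with the rest of the molecule unchanged. This single change removes the ethyl, adds the amide hydrogen and adds two fluorines at once, so the step cannot be divided among them. Nothing measured here explains the step. Still open, as far as these compounds go, is whether plain benzylamino, with no fluorine on the ring, would give a similar number. Also open, from the compounds shown here alone, is how a single fluorine or a chlorine on that ring would compare.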